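Adding a fluoro group to compound 2

A few compounds are considered here, and "the series" means these few. Any claim that something is new, unique, unknown or untested is made for them only; others in the source may bear on it.

compound 1 `Nc1ccccc1NC(=O)c1ccc(NC(=S)NCc2ccc(Cl)nc2)cc1`: 42000 nM
compound 2 `Nc1ccccc1NC(=O)c1ccc(NC(=S)NCc2cccnc2)cc1`: "not determined" (no result reported)

Two compounds have been taken into a functional assay on MDA-MB-231 cells (Homo sapiens) for cytotoxicity, read by MTT assay, with a stated time of 72 h (on this read-out higher numbers stand for weaker inhibition and lower numbers for stronger inhibition), so far, and only one of them yielded a number. Within the data shown here, there, compound 1 gives 42000 nM as the sole measured value. The entry for compound 2 reads "not determined" (no result reported) and no more, so compound 2 has no place on the scale and cannot be ranked against compound 1.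

The next structure, still unmeasured, is compound 3 `Nc1ccccc1NC(=O)c1ccc(NC(=S)NCc2cncc(F)c2)cc1` here. The change fluoro in place of hydrogen on an aromatic carbon puts fluoro in place of hydrogen on an aromatic carbon, turning pyridin-3-yl into 5-fluoropyridin-3-yl, two atoms from the ring nitrogen.

Among the measured compounds shown here, no measured step exists to size this change, and its starting point has no number. The expectation is therefore a step no larger than the usual scatter in this assay, with neither direction favoured. For the measured compounds named here, the only anchor is compound 1 at 42000 nM in the same test, and a wide margin is needed. Compound 3 is expected near 35000 nM in this test, with an estimated range running from 10000 nM to 100000 nM at its two ends.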

Compound 3, half-maximal inhibitory concentration: 85000 nM
Beside the measured number, compound 3's estimate is 2.4-fold (0.39 log units) below it; measured number inside the range.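

In this assay, among these compounds, putting 5-fluoropyridin-3-yl in place of 6-chloropyridin-3-yl gives a 2.0-fold higher number from compound 1 to compound 3 (0.31 log units; beyond the scatter), the first step that can be read. It shows that this part of the molecule can move the read-out beyond the scatter, in the direction of weaker inhibition, although the halogen and its place on the ring change together in this step. The step from compound 2 to compound 3 cannot be read, as compound 2 has no number, and nothing measured here accounts for the difference between compound 1 and compound 3.

From the compounds shown here alone, the size of fluoro in place of hydrogen on its own therefore remains unknown, and so does how much of the step belongs to the loss of the chloro group and how much to the arrival of the fluoro group. Going by these compounds, it also remains open how a methoxy group or an amino group, two atoms from the ring nitrogen on the same pyridine ring, would read in this assay.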